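Rearranging the saturated end-group of compound 1

This account rests on a few compounds, and the source may have more. Where it says the series, first, only, none or still open, it means among the compounds named here.

For the measured compounds named here, compound 1 `CC[C@@H]1C[C@H](CC)CN(CCCNC(=O)C2CCN(Cc3nc(-c4ccccc4C)oc3C)CC2)C1` gives 1270 10^-6 cm/s in a physicochemical assay for permeability, using PAMPA (a lower number here means that the compound crosses the layer more slowly, a higher number that the compound crosses the layer faster), the highest of the three numbers measured so far. Going by the values given here, compound 2 `Cc1oc(-c2c(C)c(C)c(C)c(C)c2C)nc1CN1CCC(C(=O)NCCCN2C[C@H](C)C[C@H](C)C2)CC1` gives 455 10^-6 cm/s in this assay, and compound 3 `CC[C@@H]1C[C@H](CC)CN(CCCNC(=O)C2CCN(Cc3nc(-c4c(F)cccc4F)oc3C)CC2)C1` gives 130 10^-6 cm/s; the only one-place step measured, a 9.8-fold lower number from compound 1 to compound 3 (0.99 log units; beyond the scatter), concerns the aromatic end of the molecule. Compound 4 `Cc1ccccc1-c1nc(CN2CCC(C(=O)NCCCN3CCCC(CC(C)C)C3)CC2)c(C)o1` differs from compound 1 at the other end: a group of 10 heavy atoms (9 carbon, 1 nitrogen; one six-membered non-aromatic ring with 1 hetero atom) in place of a group of 10 heavy atoms (9 carbon, 1 nitrogen; one six-membered non-aromatic ring with 1 hetero atom), on a saturated chain carbon, three bonds along the chain from an amide-type nitrogen. Among the compounds with values here, no measured step touches this part of the series, and compound 2 differs from compound 1 in more than one place, so its value cannot be read as a step. With the same atoms merely joined differently, no shift beyond the scatter is expected; the expected step is no change at the digits printed from compound 1 to compound 4 (within the scatter). The estimate for compound 4 is 1270 10^-6 cm/s, ranging from 650 10^-6 cm/s to 2500 10^-6 cm/s.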

Compound 4, apparent permeability: 3 10^-6 cm/s
Beside the measured number, compound 4's estimate is 420-fold (2.63 log units) above it, and the stated range ends above it.
By their numbers in this assay, from the lowest: compound 4; then compound 3; then compound 2; then compound 1.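

In this assay, the two end-groups on the saturated chain carbon, three bonds along the chain from an amide-type nitrogen, are not interchangeable despite having the same atoms: the change gives a 420-fold lower number from compound 1 to compound 4 (2.63 log units; beyond the scatter) at this position. That step exceeds the aromatic one, a 9.8-fold lower number from compound 1 to compound 3 (0.99 log units; beyond the scatter), so this end of the series cannot be treated as tolerant of rearrangement.

From the compounds shown here alone, whether a simpler end-group, such as unsubstituted piperidin-1-yl or morpholin-4-yl, would stay nearer compound 1 or nearer compound 4 remains open. No measurement here accounts for the size of this step.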